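This account rests on a few compounds, and the source may have more. Where it says the series, first, only, none or still open, it means among the compounds named here.

Measured in an assay on isolated protein for inhibition of Calpain-1 catalytic subunit (Sus scrofa), read by FRET; a lower number here means a stronger inhibitor, a higher number a weaker inhibitor:

Compound 1 `O=C(O)/C(S)=C/c1ccc(Cl)cc1`: 2600 nM
Compound 2 `O=C(O)/C(S)=C/c1cccc(F)c1`: 19000 nM
Compound 3 `O=C(O)/C(S)=C/c1ccccc1Cl`: 11900 nM

Compound 1 gives the lowest number of the three; compound 3 sits beyond the scatter above it, and compound 2 lies furthest off. Within the data shown here, no pair of measured compounds differs in only one place, so no single-change step is known. Compound 4 `O=C(O)/C(S)=C/c1ccc(Br)cc1` is not yet measured. It differs from compound 1 by bromo in place of chloro on an aromatic carbon. Nothing measured here shows what a halogen swap of this kind does, so the expectation rests on compound 1 alone with 2600 nM as the anchor. The step of a 1.3-fold lower number from compound 1 to compound 4 (0.11 log units; within the scatter) is expected to be small, with no clear direction, and most likely within the scatter. Compound 4 is thus estimated at 2000 nM, in a range from 800 nM to 5000 nM.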

Compound 4, half-maximal inhibitory concentration: 1500 nM
Estimate against measurement, compound 4: 1.3-fold (0.12 log units) above; the measured number falls inside the stated range.
By their numbers in this assay, from the lowest: compounds 4 and 1 (each within the scatter of the next); then compounds 3 and 2 (each within the scatter of the next).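

Among these compounds, the first single-change step, bromo in place of chloro on an aromatic carbon, reads in this assay as a 1.7-fold lower number from compound 1 to compound 4 (0.24 log units; within the scatter) and so does not separate the two halogens. At this place, para to a group of 6 heavy atoms, bromo serves as well as chloro. No supporting measurement bears on this result.

Still open, going by these compounds, is how fluoro or iodo would read at this same place. Also open, on these data alone, is whether a group other than a halogen, such as methoxy or an amine, would hold the number there.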